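Trifluoromethyl to methyl: one change, one open number

The source may report more compounds than this note shows. Statements on the series, on what has been measured and on what is new or still open speak of the compounds shown alone.

Measured so far in an ADME assay on microsomes from liver (Homo sapiens) for metabolic stability; on this read-out higher numbers stand for fast clearance and lower numbers for slow clearance:
Compound 1 `CNC(=O)c1cnc(Nc2ccc(OC)cc2C)nc1NC1CCCC1`: 37 mL.min-1.g-1
Compound 2 `CN(Cc1ccc2nccn2c1)c1nnc(-c2ccc(-c3ccccc3Cl)nc2)o1`: 92 mL.min-1.g-1
Compound 3 `CNC(=O)c1sc(N2CC3CC2(CNC(=O)c2c[nH]c4ncc(C(F)(F)F)cc24)C3)nc1C(F)(F)F`: 130 mL.min-1.g-1

For the measured compounds named here, the three compounds differ from one another in more than one place, so no measured step isolates a single structural change. Their values still give a frame. Compound 3, at 130 mL.min-1.g-1, lies within the usual scatter of compound 2, at 92 mL.min-1.g-1. Compound 1, at 37 mL.min-1.g-1, has a lower number than compound 3, and that gap lies beyond the scatter.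

Compound 4 `CNC(=O)c1sc(N2CC3CC2(CNC(=O)c2c[nH]c4ncc(C)cc24)C3)nc1C(F)(F)F` has not yet been measured. It differs from compound 3 in one place: methyl in place of trifluoromethyl on an aromatic carbon. Compound 3 carries trifluoromethyl at this spot and compound 4 carries methyl, and the spot is an aromatic carbon of a six-membered aromatic ring with 1 nitrogen, part of a fused or bridged system of two rings.

Going by the values given here, none of the measured compounds shows what this exchange does in this assay, so the expectation starts from compound 3 at 130 mL.min-1.g-1 and assumes no shift beyond the scatter. The expected step, a 1.1-fold lower number from compound 3 to compound 4 (0.05 log units; within the scatter), is small and stays within the scatter. For compound 4 the estimated value is 115 mL.min-1.g-1, with an expected range of 55 mL.min-1.g-1 to 240 mL.min-1.g-1.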

Compound 4, intrinsic clearance in microsomes: > 270 mL.min-1.g-1
Compound 4 ended at the assay's limit (the forecaster's own chance of this, stated with the estimate: 10%); at least 2.3-fold (0.37 log units) between middle value and limit.
By their numbers in this assay, from the lowest: compound 1; then compounds 2 and 3 (each within the scatter of the next). At a limit, above all of these: compound 4.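

For the compounds shown here, until now, no measured pair isolated any single exchange, and compounds 1 to 3 gave only a general frame for the read-out. In this assay, going by these compounds alone, methyl in place of trifluoromethyl on this aromatic carbon now gives an at least 2.0-fold higher number from compound 3 to compound 4 (0.31 log units; beyond the scatter), so this position of the shared core is not silent: the one exchange, on a carbon two atoms from the ring nitrogen, moves the number beyond the scatter and towards faster clearance. Compound 4 gives > 270 mL.min-1.g-1, which is a limit of the assay and not a number, so the step has a lower bound but no upper one, and its full size stays unknown: the limit of > 270 mL.min-1.g-1 in this assay, at which 1 of the 4 values shown sits.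

What the compounds leave open is why the number moves, since this one pair cannot separate the departure of trifluoromethyl from the arrival of methyl. They also do not show how the read-out would respond to a nitrile, a single fluorine atom or a cyclopropyl group on the same aromatic carbon, so the effect of this position is known for one exchange only.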